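Bromo Enters the Thiophen-2-yl Group of Compound 3

The compounds below may be only part of what the source reports. "The series", "measured", "known", "first", "only" and "open" are said of these compounds alone.

Three compounds built on the core of compound 1 `COc1ccc(-c2cc3ccccc3nc2/C=C/C(=O)c2ccc(F)cc2)cc1` have been measured in a functional assay on SK-BR-3 cells (Homo sapiens) for antiproliferative activity, read by XTT assay, with a stated time of 72 h; a lower number here means a stronger inhibitor, a higher number a weaker inhibitor. Compound 1 gives 810 nM. Compound 2 `COc1ccc(-c2cc3ccccc3nc2/C=C/C(=O)c2c(OC)cccc2OC)cc1`, which carries a 2,6-dimethoxyphenyl on the carbonyl carbon, gives 3830 nM, and compound 3 `COc1ccc(-c2cc3ccccc3nc2/C=C/C(=O)c2cccs2)cc1`, with a thiophen-2-yl on that carbonyl carbon, gives 800 nM. Compound 3 holds the lowest of the three numbers, though its gap to compound 1 stays within the scatter, as the step of a 1.0-fold lower number from compound 1 to compound 3 (0.01 log units; within the scatter) shows; the step of a 4.8-fold lower number from compound 2 to compound 3 (0.68 log units; beyond the scatter) lies beyond the scatter, and the step of a 4.7-fold higher number from compound 1 to compound 2 (0.67 log units; beyond the scatter) is of like size in the opposite sense.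

Compound 4 `COc1ccc(-c2cc3ccccc3nc2/C=C/C(=O)c2ccc(Br)s2)cc1` differs from compound 3 in one place: bromo in place of hydrogen on an aromatic carbon, so that the (thiophen-2-yl)carbonyl becomes a (5-bromothiophen-2-yl)carbonyl. Among the compounds with values here, none of the measured steps puts a bromo in place of hydrogen; all three exchange the whole aryl group on the carbonyl carbon, and even those exchanges moved this assay by a modest amount at most. The added bromo is therefore expected to shift the number only slightly, with no step beyond the scatter, as a 1.1-fold lower number from compound 3 to compound 4 (0.06 log units; within the scatter). Compound 4 is expected to give about 700 nM, within a range of 300 nM to 1800 nM.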

Compound 4, half-maximal inhibitory concentration: 520 nM
Estimate against measurement, compound 4: 1.3-fold (0.13 log units) above; low and high end bracket the measured number.
By their numbers in this assay, from the lowest: compounds 4, 3 and 1 (each within the scatter of the next); then compound 2.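

In this assay, the step of a 1.5-fold lower number from compound 3 to compound 4 (0.19 log units; within the scatter) lies within the scatter, so a single bromo on this aromatic carbon, next to the ring sulfur and two ring bonds from the ring atom that bears a large group, brings no change that can be read. The 5-bromothiophen-2-yl group likewise stands level with the 4-fluorophenyl group, with a 1.6-fold lower number from compound 1 to compound 4 (0.19 log units; within the scatter) also within the scatter, whereas a 7.4-fold lower number from compound 2 to compound 4 (0.87 log units; beyond the scatter) lies beyond the scatter and is the largest step among these four compounds, which leaves the 2,6-dimethoxyphenyl group of compound 2 apart from the other three. Nothing measured here speaks to what lies behind these numbers.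

The compounds shown leave open whether another group at this same place, such as an amine, a carboxylic acid or a longer chain, would move the number beyond the scatter. They also leave open whether a bromo on the other carbons of the five-membered aromatic ring would read the same way in this assay as it does here.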